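The source may report more compounds than this note shows. Statements on the series, on what has been measured and on what is new or still open speak of the compounds shown alone.

Compound 1 `Cc1cc(C(=O)Nc2ccc(Cl)cc2)ccc1N(CC(=O)N1CCOCC1)C(=O)Nc1ccc(Cl)cc1`: in an ADME assay on microsomes from liver (Rattus norvegicus) for metabolic stability (a higher number here means that the compound lasts longer, a lower number that the compound disappears faster), compound 1 gives 0.765 h.
Compound 2 `Cc1cc(C(=O)Nc2ccc(Cl)cc2)ccc1N(CCN1CCCC1)C(=O)Nc1ccc(Cl)cc1`: in this assay compound 2 gives 0.455 h.

Among these two numbers compound 2 stands lowest, with compound 1 as its only neighbour; the step of a 1.7-fold lower number from compound 1 to compound 2 (0.23 log units; within the scatter) stays within the scatter. Compound 3 `Cc1cc(C(=O)Nc2ccc(Cl)cc2)ccc1N(CCN1CCOCC1=O)C(=O)Nc1ccc(Cl)cc1` differs from compound 2 by 3-oxomorpholin-4-yl in place of pyrrolidin-1-yl on a saturated chain carbon, two bonds along the chain from an amide-type nitrogen. For the measured compounds named here, the one measured step that bears on this change is a 1.7-fold lower number from compound 1 to compound 2 (0.23 log units; within the scatter), which likewise swapped the group carried on this chain and did not move the number beyond the scatter. Going by the values given here, compound 3 carries a group that, like the one in compound 1, holds a carbonyl on a morpholine ring, so it is expected to sit between compound 2 and compound 1, with the step of a 1.3-fold higher number from compound 2 to compound 3 (0.12 log units; within the scatter) not clearing the scatter. Compound 3 is therefore estimated at 0.6 h, within 0.3 h to 1.2 h.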

Compound 3, half-life: 0.178 h
Estimate against measurement, compound 3: 3.4-fold (0.53 log units) above, and the stated range ends above it.
By their numbers in this assay, from the lowest: compound 3; then compounds 2 and 1 (each within the scatter of the next).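

In this assay, this position turns out to be able to move the number beyond the scatter: placing 3-oxomorpholin-4-yl on this chain gives a 2.6-fold lower number from compound 2 to compound 3 (0.41 log units; beyond the scatter), whereas the earlier change on the same chain had stayed within it. A carbonyl on a morpholine ring did not place compound 3 alongside compound 1, as the step reads a 4.3-fold lower number from compound 1 to compound 3 (0.63 log units; beyond the scatter), which leaves compound 3 lowest of the three, beyond the scatter of both others. Nothing available explains either step.

From the compounds shown here alone, it remains open whether the lower number goes with the ring carbonyl or with the six-membered ring itself, which a plain morpholin-4-yl group on the same chain would separate. Going by these compounds, how an open-chain dimethylamino group or a longer chain would behave at this place also remains open.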